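From oxan-4-yl to 4-fluorophenyl on a carbonyl carbon

This account rests on a few compounds, and the source may have more. Where it says the series, first, only, none or still open, it means among the compounds named here.

Compound 1 `O=C(NCc1cccnc1)Nc1ccc(CN2C(=O)c3ccccc3C2=O)cc1` - "not determined" (no result reported)
Compound 2 `CC[C@H](NC(=O)c1ccccc1)c1ccc(NC(=O)[C@H]2C[C@@H]2c2cccnc2)cc1` - 137 nM
Compound 3 `C[C@H](NC(=O)C1CCOCC1)c1ccc(NC(=O)[C@H]2C[C@@H]2c2cccnc2)cc1` - 7 nM

In a functional assay on COR-L23 cells (Homo sapiens) for antiproliferative activity, read by CellTiter-Glo, with a stated time of 4 days (a lower number here means a stronger inhibitor, a higher number a weaker inhibitor), compound 3 gives 7 nM and so holds the lower of the two numbers, beyond the scatter from compound 2. Compound 4 `C[C@H](NC(=O)c1ccc(F)cc1)c1ccc(NC(=O)[C@H]2C[C@@H]2c2cccnc2)cc1` has not yet been measured. Its difference from compound 3, (4-fluorophenyl in place of oxan-4-yl on a carbonyl carbon), puts 4-fluorophenyl in place of oxan-4-yl on a carbonyl carbon. For the measured compounds named here, no measured pair isolates this change. Compound 2 also has an aromatic ring on that carbonyl, though it differs elsewhere too, and it gives 137 nM in this assay, so a moderate rise, probably beyond the scatter, is expected. The estimated change is a 3.6-fold higher number from compound 3 to compound 4 (0.55 log units; beyond the scatter) in this measurement. For compound 4 the estimated value is 25 nM, with 6 nM to 100 nM as its expected range.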

Compound 4, half-maximal inhibitory concentration: 12 nM
The estimate for compound 4 lay 2.1-fold (0.32 log units) above the measured number; the measured number falls inside the stated range.
By their numbers in this assay, from the lowest: compounds 3 and 4 (each within the scatter of the next); then compound 2.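

In this assay, the step of a 1.7-fold higher number from compound 3 to compound 4 (0.23 log units; within the scatter) shows that this position on the carbonyl carbon takes an aromatic ring of carbon only as well as the non-aromatic oxan-4-yl ring. The ring oxygen, the one hydrogen-bond acceptor that leaves, can go with no change beyond the scatter. Nothing available here accounts for the two groups reading alike.

The compounds shown leave open whether an amine, a carboxylic acid or a longer chain on that carbonyl carbon would hold the number at this level, and what the fluorine of 4-fluorophenyl contributes on its own.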